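A few compounds are considered here, and "the series" means these few. Any claim that something is new, unique, unknown or untested is made for them only; others in the source may bear on it.

Of the compounds shown here, three that share one core have been measured in a physicochemical assay for solubility; on this read-out lower numbers stand for lower solubility and higher numbers for higher solubility: compound 1 `O=C(c1ccccc1)N1CCC(NS(=O)(=O)c2cc(S(=O)(=O)c3ccccc3)ccc2C(F)(F)F)CC1` gives 12500 nM, compound 2 `O=C(c1ccccn1)N1CCC(NS(=O)(=O)c2cc(S(=O)(=O)c3ccccc3)ccc2C(F)(F)F)CC1` gives 100000 nM and compound 3 `O=C(O)CCCC(=O)N1CCC(NS(=O)(=O)c2cc(S(=O)(=O)c3ccccc3)ccc2C(F)(F)F)CC1` gives 50000 nM. Compound 3 cannot be separated from compound 2, since a 2.0-fold lower number from compound 2 to compound 3 (0.30 log units; within the scatter) stays within the scatter. Compound 1 is clearly lower than both, with an 8.0-fold higher number from compound 1 to compound 2 (0.90 log units; beyond the scatter) and a 4.0-fold higher number from compound 1 to compound 3 (0.60 log units; beyond the scatter), modest steps beyond the scatter.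

The next compound is compound 4 `CC(C)(C)OC(=O)N1CCC[C@@H]1C(=O)N1CCC(NS(=O)(=O)c2cc(S(=O)(=O)c3ccccc3)ccc2C(F)(F)F)CC1`. It has 1-(tert-butoxycarbonyl)pyrrolidin-2-yl in place of 3-carboxypropyl on a carbonyl carbon.

All three measured steps change this same place, but none brings in the new group, so the evidence is indirect. The closest guide is a 4.0-fold higher number from compound 1 to compound 3 (0.60 log units; beyond the scatter), read backwards, since compound 4 also gives up the 3-carboxypropyl group. A modest fall in this assay is therefore expected, of about that size. Compound 2 goes against this simple reading, as it lacks that group too and still gives 100000 nM, so the range must stay wide on the upper side.

The estimated step is a 4.0-fold lower number from compound 3 to compound 4 (0.60 log units; beyond the scatter).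

For compound 4 the estimated value is 12500 nM, with an expected range from 3000 nM to 50000 nM.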

Compound 4, solubility: 25000 nM
Compound 4: middle estimate off by 2.0-fold (0.30 log units), on the low side, and the stated range covers the measured number.
By their numbers in this assay, from the lowest: compounds 1, 4, 3 and 2 (each within the scatter of the next, the first and the last beyond it).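

In this assay, replacing 3-carboxypropyl with 1-(tert-butoxycarbonyl)pyrrolidin-2-yl on this carbonyl carbon gives a 2.0-fold lower number from compound 3 to compound 4 (0.30 log units; within the scatter), so a group with more heavy atoms, a five-membered ring and no hydrogen-bond donor can stand here without a change that the read-out can separate from scatter. The comparison with the pyridin-2-yl compound does separate, at a 4.0-fold lower number from compound 2 to compound 4 (0.60 log units; beyond the scatter), whereas the comparison with the phenyl compound does not, at a 2.0-fold higher number from compound 1 to compound 4 (0.30 log units; within the scatter); compound 4 therefore cannot be told apart from either compound 1 or compound 3, even though those two are separated from each other. Nothing measured here explains these differences or assigns them to any feature of the groups.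

On these data alone, it remains open which part of the new group matters, and the pyrrolidin-2-yl group with its ring amine free, or with the opposite stereocentre, would help to settle that. A plain carbon chain without the carboxylic acid, compared with compound 3, would likewise show whether the acid itself or the chain carries the number seen for that compound.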